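The source may hold more compounds than are shown below. What is called first, only, known or untested is meant among the compounds shown, and "the series" means these compounds.

Measured in a functional assay on HepG2 cells (Homo sapiens) for cytotoxicity, read by MTT assay, with a stated time of 24 h; a higher number here means a weaker inhibitor, a lower number a stronger inhibitor:
- compound 1 `O=C1/C(=C/c2ccccc2F)CN(S(=O)(=O)c2ccc(F)cc2)C/C1=C\c1ccccc1F`: 7220 nM
- compound 2 `N#Cc1ccc(/C=C2\CN(S(=O)(=O)c3ccc(F)cc3)C/C(=C\c3ccc(C#N)cc3)C2=O)cc1`: 11500 nM
- compound 3 `CC(=O)Nc1ccc(S(=O)(=O)N2C/C(=C\c3cccc([N+](=O)[O-])c3)C(=O)/C(=C/c3cccc([N+](=O)[O-])c3)C2)cc1`: 7140 nM

All three values lie within the usual scatter of one another, so compound 3 cannot be separated from the other two. Compound 4 `COc1cc(/C=C2\CN(S(=O)(=O)c3ccc(NC(C)=O)cc3)C/C(=C\c3cccc([N+](=O)[O-])c3)C2=O)cc(OC)c1OC` differs from compound 3 at one place: 3,4,5-trimethoxyphenyl in place of 3-nitrophenyl on a double-bonded chain carbon bound to a double-bonded ring carbon. It has 3,4,5-trimethoxyphenyl in place of 3-nitrophenyl. Within the data shown here, no single-change step has been measured to serve as a guide. Compound 2, at 11500 nM, differs from compound 3 in more than one place, yet their values stay within the scatter. In this assay, no step beyond the scatter is therefore expected, in either direction. The expected step is small, a 1.2-fold lower number from compound 3 to compound 4 (0.08 log units; within the scatter). For compound 4 the estimated value is 6000 nM, with an expected range of 2500 nM to 14000 nM.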

Compound 4, half-maximal inhibitory concentration: 3340 nM
Compound 4: the middle estimate sits 1.8-fold (0.25 log units) above what was measured; the range from low to high includes it.
By their numbers in this assay, from the lowest: compound 4; then compounds 3, 1 and 2 (each within the scatter of the next).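

In this assay, among these compounds, this is the first single change that moves the number beyond the scatter: 3,4,5-trimethoxyphenyl in place of 3-nitrophenyl gives a 2.1-fold lower number from compound 3 to compound 4 (0.33 log units; beyond the scatter). The step is modest, but it shows that the group on this double-bonded chain carbon can affect cytotoxicity. Nothing measured here says why the step occurs. As far as these compounds go, it remains open whether an amine or a carboxylic acid at this place would shift the number further. Also open, from the compounds shown here alone, is whether replacing the second 3-nitrophenyl, which compound 4 keeps, would add to the step.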